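The compounds below may be only part of what the source reports. "The series", "measured", "known", "first", "only" and "open" are said of these compounds alone.

Compound 1 `Cc1nc2ccc(F)cc2n1-c1ccc(C(=O)NC2CC2)s1` gives > 72 mL/min/kg (a limit of the assay)
Compound 2 `Cc1nc2c(Cl)cccc2n1-c1ccc(C(=O)NC2CC2)s1` gives 19 mL/min/kg

Among the compounds with values here, in an in vitro ADME assay on microsomes from liver (Mus musculus) for pharmacokinetics, read by LC-MS (a higher number here means faster removal of the compound, a lower number slower removal), compound 2 gives 19 mL/min/kg as the only actual number so far. Compound 1 gives > 72 mL/min/kg as a limit, not a number. Compound 3 `Cc1nc2c(Cl)cc(F)cc2n1-c1ccc(C(=O)NC2CC2)s1` differs from compound 2 by fluoro in place of hydrogen on an aromatic carbon as fluoro in place of hydrogen on an aromatic carbon. Within the data shown here, compound 1 also carries fluoro but lacks the chloro group, so no measured pair shows this change alone. The estimated step of a 1.1-fold higher number from compound 2 to compound 3 (0.02 log units; within the scatter) is expected to stay within the usual scatter, in neither direction. Compound 3 is estimated at 20 mL/min/kg with an expected range from 10 mL/min/kg to 42 mL/min/kg for the measurement.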

Compound 3, clearance: 42 mL/min/kg
Compound 3: the middle estimate sits 2.1-fold (0.32 log units) below what was measured, within the range that was stated.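

In this assay, within the data shown here, fluoro in place of hydrogen on this aromatic carbon gives a 2.2-fold higher number from compound 2 to compound 3 (0.34 log units; beyond the scatter), the first measured pair to show this change alone, and the change is modest. Chloro in place of hydrogen gives an at least 1.7-fold lower number from compound 1 to compound 3 (0.23 log units; that floor lies within the scatter), so this step shows a direction only weakly. That step starts from a limit, not a number: the limit of > 72 mL/min/kg in this assay, at which 1 of the 3 values shown sits.

From the compounds shown here alone, how an amine or a nitrile at the fluoro position would compare remains open. Going by these compounds, the true size of the chloro step also remains open.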